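This account rests on a few compounds, and the source may have more. Where it says the series, first, only, none or still open, it means among the compounds named here.

The measured compounds, with their readings in an ADME assay on Li23 cells (Homo sapiens) for cytotoxicity, read by WST assay; on this read-out lower numbers stand for higher toxicity in this test and higher numbers for lower toxicity in this test:

Compound 1 `Cc1cc(N(C)C(=O)c2ccccc2)ccc1C(O)(C(F)(F)F)C(F)(F)F` gives 87000 nM.
Compound 2 `Cc1ccc(C(=O)N(C)c2ccc(C(O)(C(F)(F)F)C(F)(F)F)cc2)cc1` gives 26000 nM.
Compound 3 `CCCC(=O)N(C)c1ccc(C(O)(C(F)(F)F)C(F)(F)F)cc1` gives only a limit of the assay, > 100000 nM.

Within the data shown here, compound 3 therefore stands at the edge of what this assay can report: its reading is a limit and not a number, and it is the one compound of the three that sits there (the limit of > 100000 nM in this assay, at which 1 of the 3 values shown sits). Among the measured compounds shown here, the single measured change in one place is the step from the 4-methylphenyl amide to the propyl amide: an at least 3.8-fold higher number from compound 2 to compound 3 (0.58 log units; beyond the scatter). Compound 1 also carries an aromatic ring on the carbonyl carbon, but its core differs from the others, so its value and that of compound 2 can only be set side by side.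

Compound 4 `CN(C(=O)c1cccnc1)c1ccc(C(O)(C(F)(F)F)C(F)(F)F)cc1` is compound 3 with one change: pyridin-3-yl in place of propyl on a carbonyl carbon. This brings an aromatic ring back onto the carbonyl carbon, reversing the measured step. Because an at least 3.8-fold higher number from compound 2 to compound 3 (0.58 log units; beyond the scatter) rose when the aromatic ring left, a return of an aromatic ring is expected to pull the number back down toward a measurable value. Compound 4 is thus estimated at 60000 nM, with a range from 25000 nM to 150000 nM, an expected step of an at least 1.6-fold lower number from compound 3 to compound 4 (0.22 log units; that floor lies within the scatter), though a limit may again be reported.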

Compound 4, half-maximal cytotoxic concentration: 63000 nM
Compound 4: middle estimate off by 1.1-fold (0.02 log units), on the low side, and the stated range covers the measured number.
By their numbers in this assay, from the lowest: compound 2; then compounds 4 and 1 (each within the scatter of the next). At a limit, above all of these: compound 3.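

Putting pyridin-3-yl in place of propyl on a carbonyl carbon gives an at least 1.5-fold lower number from compound 3 to compound 4 (0.20 log units; that floor lies within the scatter), and with it a reading in this assay that is a number. The size of this step remains a floor, because compound 3 stands at a limit and not at a number: the limit of > 100000 nM in this assay, at which 1 of the 4 values shown sits. The two aromatic groups tried on this carbonyl carbon of the shared core also do not read alike: pyridin-3-yl in place of 4-methylphenyl gives a 2.4-fold higher number from compound 2 to compound 4 (0.38 log units; beyond the scatter), so in this pair the number depends on which aromatic group is present, not only on an aromatic ring being there.

That last step changes two things at once, a ring carbon for a ring nitrogen and the loss of the methyl group, and the compounds shown do not separate them, which a plain phenyl group on this same core could do. Also open, on these data alone, is where this assay would place a longer chain such as hexyl in place of propyl, or a pyridin-3-yl group carrying an amine.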